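Aryl swap on the shared core: from nitrophenyl to thiophene

This account rests on a few compounds, and the source may have more. Where it says the series, first, only, none or still open, it means among the compounds named here.

Compound 1 `COc1ccc(C(C2=C(O)C(=O)c3ccccc3C2=O)c2c[nH]c3ccccc23)cc1Br` gives 7320 nM in a functional assay on HeLa cells (Homo sapiens) for cytotoxicity, read by MTT assay, with a stated time of 48 h; on this read-out lower numbers stand for stronger inhibition and higher numbers for weaker inhibition.
Compound 2 `O=C1C(O)=C(C(c2ccc([N+](=O)[O-])cc2)c2c[nH]c3ccccc23)C(=O)c2ccccc21` gives 14800 nM in this assay.

Within the data shown here, compound 2 stands highest of the two numbers; the only measured step, a 2.0-fold higher number from compound 1 to compound 2 (0.31 log units; beyond the scatter), is modest yet beyond the scatter. Compound 3 `O=C1C(O)=C(C(c2cccs2)c2c[nH]c3ccccc23)C(=O)c2ccccc21` differs from compound 2 by thiophen-2-yl in place of 4-nitrophenyl on a saturated chain carbon bound to an aromatic carbon and a double-bonded ring carbon. Among the measured compounds shown here, that measured step bears on it only in that both exchange the aryl group at the same place; no measured compound carries thiophen-2-yl. A modest step in this assay is therefore expected, with uncertain direction. Compound 3 is estimated at 9000 nM, within 3000 nM to 30000 nM. This estimate corresponds to an expected 1.6-fold lower number from compound 2 to compound 3 (0.22 log units; within the scatter).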

Compound 3, half-maximal inhibitory concentration: 12400 nM
Compound 3: the middle estimate sits 1.4-fold (0.14 log units) below what was measured, and the stated range covers the measured number.
By their numbers in this assay, from the lowest: compounds 1, 3 and 2 (each within the scatter of the next, the first and the last beyond it).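

At this place, a five-membered aromatic ring with one sulfur stands in for either six-membered aromatic ring with no step beyond the scatter in this assay, both (a 1.2-fold lower number from compound 2 to compound 3 (0.08 log units; within the scatter)) and (a 1.7-fold higher number from compound 1 to compound 3 (0.23 log units; within the scatter)). Compound 3 thus lies within the scatter of both compound 1 and compound 2, although those two lie beyond it from each other. No evidence is at hand to account for this. From the compounds shown here alone, it remains open how a cyclohexyl group or a chain carrying an amine would read at this place, since all three compounds carry an aromatic ring there.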